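A few compounds are considered here, and "the series" means these few. Any claim that something is new, unique, unknown or untested is made for them only; others in the source may bear on it.

In a functional assay on MCF7 cells (Homo sapiens) for inhibition, read by CCK-8 assay, with a stated time of 48 h (on this read-out lower numbers stand for stronger inhibition of growth and higher numbers for weaker inhibition of growth), three compounds that share one core have been measured. Compound 1 (`COc1cccc(CNc2nc(Nc3ccc(N4CCN(C)CC4)cn3)ncc2Cl)c1`), with 3-methoxybenzyl on a nitrogen on an aromatic ring, gives 19500 nM. Compound 2 (`CN1CCN(c2ccc(Nc3ncc(Cl)c(NCc4ccco4)n3)nc2)CC1`), with (furan-2-yl)methyl there, gives 21300 nM. Compound 3 (`Cc1ccc(Nc2nc(Nc3ccc(N4CCN(C)CC4)cn3)ncc2Cl)cc1`), with 4-methylphenyl there, gives 11400 nM. Compound 3 does not stand apart from the other two: a 1.7-fold lower number from compound 1 to compound 3 (0.23 log units; within the scatter) and a 1.9-fold lower number from compound 2 to compound 3 (0.27 log units; within the scatter) both remain within the scatter, as does a 1.1-fold higher number from compound 1 to compound 2 (0.04 log units; within the scatter).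

Compound 4 (`CCc1ccc(Nc2nc(Nc3ccc(N4CCN(C)CC4)cn3)ncc2Cl)cc1`) turns 4-methylphenyl into 4-ethylphenyl: methyl in place of hydrogen on a saturated chain carbon bound to an aromatic carbon. Within the data shown here, no measured step is this change itself. The closest evidence is the exchange of the whole group on that nitrogen, and even a 1.9-fold lower number from compound 2 to compound 3 (0.27 log units; within the scatter) stays within the scatter. No step beyond the scatter is therefore expected in this assay. The expected step is a 1.0-fold lower number from compound 3 to compound 4 (0.02 log units; within the scatter). For compound 4 the estimated value is 11000 nM, with an expected range of 6000 nM to 21000 nM.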

Compound 4, concentration for 50% growth inhibition: 8230 nM
Compound 4: the middle estimate sits 1.3-fold (0.13 log units) above what was measured; the measured number falls inside the stated range.
By their numbers in this assay, from the lowest: compounds 4, 3, 1 and 2 (each within the scatter of the next, the first and the last beyond it).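

Adding methyl on a saturated chain carbon bound to an aromatic carbon, which turns 4-methylphenyl into 4-ethylphenyl, produces no change beyond the scatter in this assay (a 1.4-fold lower number from compound 3 to compound 4 (0.14 log units; within the scatter)). The group on this nitrogen now gives the first separation beyond the scatter, though a modest one, as 4-ethylphenyl differs from (furan-2-yl)methyl (a 2.6-fold lower number from compound 2 to compound 4 (0.41 log units; beyond the scatter)) and from 3-methoxybenzyl (a 2.4-fold lower number from compound 1 to compound 4 (0.37 log units; beyond the scatter)), whereas compound 3 stays within the scatter of both compound 1 and compound 2. Nothing available here explains these differences.

The compounds shown leave open whether a longer chain such as propyl in place of ethyl, or an amine or a carboxylic acid at that place, would widen or close this separation. Also open, from the compounds shown here alone, is how unsubstituted benzyl on that nitrogen would compare with 4-ethylphenyl.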